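The compounds below may be only part of what the source reports. "The series", "measured", "known", "first", "only" and "open" are said of these compounds alone.

Compound 1, `Cc1cccc(-n2nncc2CN2C(=O)C3(C(C#N)=C(N)Oc4c(N)cc5nc6ccccc6nc5c43)c3ccccc32)c1`, gives > 50000 nM in an ADME assay on HUVEC cells (Homo sapiens) for antiproliferative activity, read by MTT assay, with a stated time of 48 h; on this read-out higher numbers stand for weaker inhibition and lower numbers for stronger inhibition; this is a limit of the assay, not a number.
Compound 2, `CCc1cccc(CC)c1-n1nncc1CN1C(=O)C2(C(C#N)=C(N)Oc3c(N)cc4nc5ccccc5nc4c32)c2ccccc21`, gives > 50000 nM in this assay; this too is a limit of the assay.

On the numbers shown, compound 2 stands only at a limit, and the limit of > 50000 nM in this assay, at which 2 of the 2 values shown sit, shows that no measured value in this series lies anywhere else. Among the compounds with values here, the one measured step, a step that the two limits leave unreadable from compound 1 to compound 2, changes the group on the aromatic nitrogen, the same place that is changed now, but with both ends at the limit its size cannot be read.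

Compound 3 is `COc1ccc(OC)c(-n2nncc2CN2C(=O)C3(C(C#N)=C(N)Oc4c(N)cc5nc6ccccc6nc5c43)c3ccccc32)c1`. The change from compound 2 to compound 3 is 2,5-dimethoxyphenyl in place of 2,6-diethylphenyl on an aromatic nitrogen. Within the data shown here, since the only step at this position is unreadable, and both measured compounds sit at the limit, there is no ground for expecting a step beyond the scatter in either direction in this assay . The expected step from compound 2 to compound 3 is therefore a step that the limit leaves unreadable from compound 2 to compound 3. Compound 3 is estimated at 70000 nM in this assay , with a range from 20000 nM to 300000 nM, and most likely again only a limit will be reported.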

Compound 3, half-maximal inhibitory concentration: > 50000 nM
Compound 3: a limit, no number; the forecaster's own chance of this, stated with the estimate: 80%; the middle value does not contradict the limit.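

Within the data shown here, no step from compound 1 or compound 2 to compound 3 can be read, as all three compounds end at the same limit of the assay: the limit of > 50000 nM in this assay, at which 3 of the 3 values shown sit. The compounds shown leave open whether any group on the aromatic nitrogen changes the result in this assay, and whether any such compound gives a real number rather than a limit.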